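Swapping the Aryl Amide on a Chemokine Receptor Ligand

The compounds below may be only part of what the source reports. "The series", "measured", "known", "first", "only" and "open" are said of these compounds alone.

Three measured compounds share one core and differ only in their two outer aryl groups. Compound 1 `O=C(NCc1ccc(CNS(=O)(=O)c2ccccc2)cc1)c1cccc(F)c1` gives 100 nM in an assay on MDA-MB-231 cells for binding affinity to C-X-C chemokine receptor type 4 (Homo sapiens), read by immunofluorescence and microscopy, with stated times of 10 min and 30 min; a higher number here means that more compound is needed for the effect, a lower number that less compound is needed. Compound 2 `COc1ccc(C(=O)NCc2ccc(CNS(=O)(=O)c3ccccc3)cc2)cc1` gives 1000 nM in this assay, and the change is a 10-fold higher number from compound 1 to compound 2 (1.00 log units; beyond the scatter). Compound 3 `COc1ccc(C(=O)NCc2ccc(CNS(=O)(=O)c3ccc(C)cc3)cc2)cc1` gives 100 nM, a change of a 10-fold lower number from compound 2 to compound 3 (1.00 log units; beyond the scatter). Compound 3 thus stands level with compound 1 at the digits shown, the two together the lowest numbers of the three, with compound 2 furthest away.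

Compound 4 `Cc1ccc(S(=O)(=O)NCc2ccc(CNC(=O)c3cccc(C)c3)cc2)cc1` differs from compound 3 by 3-methylphenyl in place of 4-methoxyphenyl on a carbonyl carbon. For the measured compounds named here, only one measured step touches the aryl group on the carbonyl carbon, a 10-fold higher number from compound 1 to compound 2 (1.00 log units; beyond the scatter), where the 4-methoxyphenyl entered and the number rose. The other step, a 10-fold lower number from compound 2 to compound 3 (1.00 log units; beyond the scatter), concerns the other ring and bears less directly. Removing the 4-methoxyphenyl again suggests the number should fall. Compound 4 is therefore expected to give about 30 nM, somewhere between 8 nM and 150 nM. The expected step is a 3.3-fold lower number from compound 3 to compound 4 (0.52 log units; beyond the scatter).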

Compound 4, effective concentration (reported as EC, without a stated level of effect): 1000 nM
Beside the measured number, compound 4's estimate is 33-fold (1.52 log units) below it; measured number above the stated range.
By their numbers in this assay, from the lowest: compounds 1 and 3 (each within the scatter of the next); then compounds 2 and 4 (each within the scatter of the next).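

At this position, the 4-methoxyphenyl group is not simply unfavourable: 3-methylphenyl in its place gives a 10-fold higher number from compound 3 to compound 4 (1.00 log units; beyond the scatter), whereas the 4-methoxyphenyl group was on the higher-number side of a 10-fold higher number from compound 1 to compound 2 (1.00 log units; beyond the scatter). The two steps have different partner groups and different rings on the sulfonyl side, so they give no single ranking of aryl groups on the carbonyl carbon, and the methyl group that accompanied a 10-fold lower number from compound 2 to compound 3 (1.00 log units; beyond the scatter) does not by itself ensure a low number, as compound 4 carries it too. No available evidence explains this reversal. As far as these compounds go, it remains open whether 3-fluorophenyl on the carbonyl carbon would keep its number alongside that methyl group. From the compounds shown here alone, the effect of an amine or a carboxylic acid on this aryl group also remains open.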